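A Smaller Amine at the End of the Chain

A few compounds are considered here, and "the series" means these few. Any claim that something is new, unique, unknown or untested is made for them only; others in the source may bear on it.

Compound 1 `CCCCNc1nc(N)nc(C)c1CCCN1CCN(C)CC1`, compound 2 `CCCCNc1nc(N)nc(C)c1CCCN1Cc2ccccc2C1` and compound 3 `CCCCNc1nc(N)nc(C)c1C#CCN1CCCCC1` share a core and differ in the group hanging off it. In an assay on HEK293 cells for agonist activity at Toll-like receptor 8 (Homo sapiens), read by spectrophotometry (on this read-out lower numbers stand for an effect already at smaller amounts and higher numbers for an effect only at larger amounts of compound), compound 1 gives 179 nM. Of the three numbers this is the second highest. In this assay compound 2 gives 29 nM, the number nearest to compound 1 and a lower one, beyond the usual scatter, so compound 2 acts at smaller amounts. In this assay compound 3 gives 3790 nM, the number furthest from compound 1 and a higher one, also beyond the scatter.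

Compound 4 `CCCCNc1nc(N)nc(C)c1CCCN(C)C` has not been measured. It differs from compound 1 in one place: dimethylamino in place of 4-methylpiperazin-1-yl on a saturated chain carbon, three bonds along the chain from an aromatic carbon. The group that leaves carries a ring; the group that enters has none. For the measured compounds named here, no measured pair isolates this change, so the size of the step is uncertain. Compound 2 shows that a different ring gives a lower number, and compound 3 shows that a different chain and ring give a much higher one, but neither tells what a small open-chain amine does. The step from compound 1 to compound 4 is expected to be a 1.7-fold higher number from compound 1 to compound 4 (0.22 log units; within the scatter), a modest rise in the number, leaning toward a weaker effect. Compound 4 is expected to give 300 nM in this assay, within a range from 70 nM to 1300 nM.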

Compound 4, half-maximal effective concentration: 126 nM
The estimate for compound 4 lay 2.4-fold (0.38 log units) above the measured number; the measured number falls inside the stated range.
By their numbers in this assay, from the lowest: compound 2; then compounds 4 and 1 (each within the scatter of the next); then compound 3.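

In this assay, putting dimethylamino in place of 4-methylpiperazin-1-yl on a saturated chain carbon, three bonds along the chain from an aromatic carbon, gives a 1.4-fold lower number from compound 1 to compound 4 (0.15 log units; within the scatter) and so leaves the two compounds indistinguishable on this read-out. For the compounds shown here, this is the first direct look at this change, and it shows that in this pair the end of the chain can lose its ring and shrink from 7 heavy atoms to 3 with no difference that stands clear of the usual scatter. No measurement of any property of these two groups accompanies the result, so the numbers alone offer no explanation for it.

The compounds shown leave open whether this tolerance extends to other open-chain groups at the same place, such as a primary amine, diethylamino or a non-basic end such as a methyl ether, as one pair cannot establish a trend. As far as these compounds go, it also remains open whether dimethylamino would give a similar number on a longer chain, or with the butylamino group on the shared core replaced by a pentylamino group.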